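The compounds below may be only part of what the source reports. "The series", "measured", "known", "first", "only" and "open" are said of these compounds alone.

Compounds measured in an ADME assay on cells (Homo sapiens) for cytotoxicity, read by polymerase chain reaction, with a stated time of 3 days (on this read-out higher numbers stand for lower toxicity in this test and lower numbers for higher toxicity in this test), so far:

Compound 1, `CCCNc1nc(C)c(-c2nc3ccccc3s2)c(N[C@@H]2C[C@H](CO)[C@@H](O)[C@H]2O)n1`. In this assay compound 1 gives > 25000 nM, which is a limit of the assay and not a number.
Compound 2, `Cc1nc(N(C)C)nc(N[C@@H]2C[C@H](CO)[C@@H](O)[C@H]2O)c1-c1nc2ccccc2s1`. In this assay compound 2 gives 18000 nM.
Compound 3, `CCOC(=O)NCCNc1nc(C)c(-c2nc3ccccc3s2)c(N[C@@H]2C[C@H](CO)[C@@H](O)[C@H]2O)n1`, not yet measured in this assay.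

Compound 2 thus holds the only number shown in this assay; the one further value is a limit. Among the compounds with values here, the single measured step, an at least 1.3-fold lower number from compound 1 to compound 2 (0.14 log units; that floor lies within the scatter), exchanged propylamino for dimethylamino on an aromatic carbon, and its floor sits within the scatter because it rests on (the limit of > 25000 nM in this assay, at which 1 of the 2 values shown sits).

Compound 3 carries (2-((ethoxycarbonyl)amino)ethyl)amino in place of dimethylamino on an aromatic carbon. Within the data shown here, the only step that bears on this change is an at least 1.3-fold lower number from compound 1 to compound 2 (0.14 log units; that floor lies within the scatter), which altered the group on the same aromatic carbon and was too small to give a direction. Among the measured compounds shown here, no step in this assay beyond the scatter is therefore expected, and the estimated step of a 1.2-fold higher number from compound 2 to compound 3 (0.09 log units; within the scatter) is taken to lie within it. Compound 3 is accordingly expected to give about 22000 nM in this assay, with a range from 9000 nM to 55000 nM, and a fair chance that only a limit is reported.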

Compound 3, half-maximal cytotoxic concentration: 12000 nM
The estimate for compound 3 lay 1.8-fold (0.26 log units) above the measured number, and the stated range covers the measured number.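

In this assay, this position now shows its first step beyond the scatter: an at least 2.0-fold lower number from compound 1 to compound 3 (0.31 log units; beyond the scatter), with (ethoxycarbonyl)amino in place of methyl on a saturated chain carbon, two bonds along the chain from a nitrogen on an aromatic ring. From the compounds shown here alone, that step is only a floor and its true size stays unknown, because compound 1 stands at a limit of the assay and not at a number: the limit of > 25000 nM in this assay, at which 1 of the 3 values shown sits. Against dimethylamino the same group gives no readable change, as a 1.5-fold lower number from compound 2 to compound 3 (0.18 log units; within the scatter) leaves the two compounds inseparable, even though a group of 3 heavy atoms gives way to one of 9 with 2 hydrogen-bond donors.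

Going by these compounds, whether the step from the propylamino compound depends on the ethoxycarbonyl group itself, or would also appear with an amine or a carboxylic acid at the end of the chain, stays open, as does the effect of a longer chain. On these data alone, all three compounds also keep the methyl group and the 1,3-benzothiazol-2-yl group, so what a change at either of those places would do in this assay remains unknown.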